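A few compounds are considered here, and "the series" means these few. Any claim that something is new, unique, unknown or untested is made for them only; others in the source may bear on it.

Measured so far:
compound 1 `COc1cccc2c1OCC(C)(C)C2N` — -0.7%
compound 2 `COc1cccc2c1C(O)C(C)(C)CO2` — 11.5%

In an assay on BTI cells for inhibition of Amine oxidase [flavin-containing] A (Homo sapiens), read by fluorescence, with a stated time of 20 min, tested at 1 uM (on this read-out lower numbers stand for less inhibition and higher numbers for more inhibition at the one concentration tested (going by the name of the read-out)), compound 1 gives -0.7%, the lowest of the two numbers; compound 2 gives 11.5%, higher by more than the scatter. Compound 3 `C#CCNC1c2cccc(OC)c2OCC1(C)C` differs from compound 1 by propargyl in place of hydrogen on an amine nitrogen. Among the measured compounds shown here, no step of this kind stands measured, so the expectation rests on nothing more than the values of compound 1 and compound 2. An upward step in this assay is expected, beyond the scatter, a number 30.7 percentage points higher from compound 1 to compound 3 (beyond the scatter). Compound 3 is estimated at 30%, with a range from 0% to 75%.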

Compound 3, a percentage reported as inhibition, at one concentration (the size of the read-out at that concentration, not a potency): 4.6%
The estimate for compound 3 lay 25.4 percentage points above the measured number; measured number inside the range.
By their numbers in this assay, from the lowest: compounds 1, 3 and 2 (each within the scatter of the next, the first and the last beyond it).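

In this assay, propargyl in place of hydrogen on an amine nitrogen gives a number 5.3 percentage points higher from compound 1 to compound 3 (within the scatter), so this position has now been probed once and the change cannot be told apart from the scatter. On this single step, the propargylamino compound does not separate from the amino compound at the one concentration tested. No supporting data bear on this reading.

Open, on these data alone, is whether a methyl group, a longer chain or an acetyl group on this nitrogen would read apart from compound 1. Also open, as far as these compounds go, is whether compound 1 and compound 3 would separate at a higher concentration.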